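The source may hold more compounds than are shown below. What is called first, only, known or untested is meant among the compounds shown, and "the series" means these compounds.

Compound 2 `COc1ccc(Nc2nccc(-c3cccnc3)n2)cc1` gives 1700 nM in a functional assay for inhibition, with Homo sapiens as the target (a higher number here means a weaker inhibitor, a lower number a stronger inhibitor), which places it second highest of the three numbers in hand: compound 1 `CC(=O)Nc1ccc(Nc2nccc(-c3cccnc3)n2)cc1` gives 3600 nM, and compound 3 `CC(C)(C)c1ccc(Nc2nccc(-c3cccnc3)n2)cc1` gives 600 nM. The steps among them, a 2.1-fold lower number from compound 1 to compound 2 (0.33 log units; beyond the scatter), a 6.0-fold lower number from compound 1 to compound 3 (0.78 log units; beyond the scatter) and a 2.8-fold lower number from compound 2 to compound 3 (0.45 log units; beyond the scatter), all concern the group on the aromatic carbon of the outer ring, where acetamido, methoxy and tert-butyl are exchanged. Compound 4 `COc1ccc(Nc2nccc(-c3ccsc3)n2)cc1` differs from compound 2 at a different part of the shared core: thiophen-3-yl in place of pyridin-3-yl on an aromatic carbon. For the measured compounds named here, no measured step touches that part, so none of the three steps bears directly on this change, and the data give no direction for it. A modest shift in either sense is possible, and a small loss is taken as the more likely outcome. The step expected from compound 2 to compound 4 is therefore a 1.6-fold higher number from compound 2 to compound 4 (0.22 log units; within the scatter). Compound 4 is accordingly expected to give about 2800 nM in this assay, within a range from 900 nM to 9000 nM.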

Compound 4, half-maximal inhibitory concentration: 15600 nM
Compound 4: the middle estimate sits 5.6-fold (0.75 log units) below what was measured, and the stated range ends below it.
By their numbers in this assay, from the lowest: compound 3; then compound 2; then compound 1; then compound 4.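

Compounds 1, 2 and 3 all carry pyridin-3-yl, so they could not show that this part of the shared core matters; in this assay, thiophen-3-yl in its place gives a 9.2-fold higher number from compound 2 to compound 4 (0.96 log units; beyond the scatter). The swap replaces a six-membered aromatic ring holding a nitrogen with a five-membered one holding a sulfur, while the counted hydrogen-bond donors and acceptors stay the same, so ring size and hetero atom change together and this single step cannot separate them. Nothing available explains why the number rises at this position.

As far as these compounds go, it remains open whether phenyl, pyridin-4-yl or furan-3-yl at this position would give a number closer to that of compound 2. Also open, from the compounds shown here alone, is whether tert-butyl or acetamido on the outer ring would shift the number with thiophen-3-yl as it does with pyridin-3-yl.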